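A new aromatic arm on the core of compound 2

A few compounds are considered here, and "the series" means these few. Any claim that something is new, unique, unknown or untested is made for them only; others in the source may bear on it.

Measured so far:
Compound 1, `CCOc1ccccc1-c1ccc(-c2nc3cnccc3cc2C#N)cc1`, gives 3.8 in a physicochemical assay for lipophilicity, read by HPLC, at pH 7.5; on this read-out lower numbers stand for lower lipophilicity and higher numbers for higher lipophilicity.
Compound 2, `CC[C@@H](Nc1c(C#N)c(-c2ccc(-c3ccncc3C)cc2)nc2cnccc12)C(N)=O`, gives 2 in this assay.

Compound 2 stands lowest of the two numbers. Its nearest neighbour is compound 1, whose value lies higher by a gap beyond the usual scatter; the two compounds differ in several places at once, so their values show only that much and nothing about any single change.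

Compound 3, `CC[C@@H](Nc1c(C#N)c(-c2ccc(-c3ccccc3CO)cc2)nc2cnccc12)C(N)=O`, has not yet been measured in this assay. It differs from compound 2 in one place: 2-(hydroxymethyl)phenyl in place of 3-methylpyridin-4-yl on an aromatic carbon. The group that leaves has a ring with one hetero atom and no hydrogen-bond donor; the group that enters has a ring of carbon only and carries a hydroxymethyl with one hydrogen-bond donor.

Within the data shown here, no measured pair shows this exact change, so the size of the step is open. The expected step is a number 0.30 log units higher from compound 2 to compound 3 (within the scatter), small and upward, perhaps not clearly beyond the scatter. Compound 3 is therefore estimated at 2.3, with a likely range from 1.7 to 2.9.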

Compound 3, distribution coefficient: 2.1
Beside the measured number, compound 3's estimate is 0.20 log units above it; the range from low to high includes it.
By their numbers in this assay, from the lowest: compounds 2 and 3 (each within the scatter of the next); then compound 1.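

Placing 2-(hydroxymethyl)phenyl in place of 3-methylpyridin-4-yl on this aromatic carbon, para to a large group, gives in this assay a change of a number 0.10 log units higher from compound 2 to compound 3 (within the scatter) and so leaves the two compounds indistinguishable on this read-out. Compound 1 could not show this, as it differs from compound 2 in several places at once, whereas this pair isolates a single position and shows that these two arms can be exchanged there with no change beyond the scatter. The exchange replaces a ring with one hetero atom and no hydrogen-bond donor with a ring of carbon only carrying a hydroxymethyl with one hydrogen-bond donor, yet no measurement here explains why the two compounds read alike.

The exchange alters the ring and its substituent together, so the compounds shown cannot say what either alteration contributes alone, and a plain phenyl ring or a pyridine ring carrying the hydroxymethyl would be needed to separate them. Also open, going by these compounds, is how an amine or a carboxylic acid in place of the hydroxymethyl would read, and whether this exchange would behave the same way on the core of compound 1.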